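Swapping the aryl ether for phenethyl: solubility expectation

The compounds below may be only part of what the source reports. "The series", "measured", "known", "first", "only" and "open" are said of these compounds alone.

Compound 1, `COc1cccc(CNCCCNc2ccnc3cc(C4CCCCC4)ccc23)c1O`, gives 4200 nM in a physicochemical assay for solubility, with a stated time of 18 h, at pH 7.4; a lower number here means a less soluble compound, a higher number a more soluble compound.
Compound 2, `COc1cccc(CNCCCNc2ccnc3cc(CCC(C)C)ccc23)c1O`, gives 4200 nM.
Compound 3, `COc1cccc(CNCCCNc2ccnc3cc(Oc4cccc(N(C)C)c4)ccc23)c1O`, gives 14500 nM.

Compound 3 stands highest of the three numbers in this assay: a 3.5-fold higher number from compound 1 to compound 3 (0.54 log units; beyond the scatter) and a 3.5-fold higher number from compound 2 to compound 3 (0.54 log units; beyond the scatter), both beyond the scatter, while no change at the digits printed from compound 1 to compound 2 (within the scatter).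

Compound 4, `COc1cccc(CNCCCNc2ccnc3cc(CCc4ccccc4)ccc23)c1O`, is made from compound 3 by one change: phenethyl in place of 3-(dimethylamino)phenoxy on an aromatic carbon. Phenethyl carries 0 hydrogen-bond acceptors where 3-(dimethylamino)phenoxy carried 2, so this step runs the earlier steps backwards. Because a 3.5-fold higher number from compound 1 to compound 3 (0.54 log units; beyond the scatter) and a 3.5-fold higher number from compound 2 to compound 3 (0.54 log units; beyond the scatter) were modest rises when 3-(dimethylamino)phenoxy entered, a modest fall is expected when it leaves, putting compound 4 near compounds 1 and 2. The expected step is a 2.9-fold lower number from compound 3 to compound 4 (0.46 log units; beyond the scatter). Compound 4 is therefore estimated at 5000 nM in this assay, with a likely range from 2000 nM to 12000 nM.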

Compound 4, solubility: 4200 nM
The estimate for compound 4 lay 1.2-fold (0.08 log units) above the measured number; the measured number falls inside the stated range.
By their numbers in this assay, from the lowest: compounds 1, 2 and 4 (each within the scatter of the next); then compound 3.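

In this assay, there is a 3.5-fold lower number from compound 3 to compound 4 (0.54 log units; beyond the scatter), whereas there is no change at the digits printed from compound 2 to compound 4 (within the scatter) and no change at the digits printed from compound 1 to compound 4 (within the scatter). Phenethyl has the same six-membered aromatic ring of carbon only as 3-(dimethylamino)phenoxy, yet compound 4 sits with the cyclohexyl and isopentyl compounds, so among these four compounds, that ring alone does not go with the higher number. Nothing available bears on the reason for this step.

The group that leaves differs from phenethyl in both its oxygen and its dimethylamino group, and the compounds shown leave open which of these, if either, goes with the higher number of compound 3. A plain phenoxy group and a phenethyl group carrying a dimethylamino group on its ring would separate the two.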